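The source may hold more compounds than are shown below. What is called first, only, known or untested is meant among the compounds shown, and "the series" means these compounds.

Measured in a physicochemical assay for lipophilicity, read by HPLC, at pH 7.4; on this read-out higher numbers stand for higher lipophilicity and lower numbers for lower lipophilicity:
- compound 1 `COCCOc1cc2oc(=O)n(CCC(=O)O)c2cc1Cl`: 0.88
- compound 2 `O=C(O)CCn1c(=O)oc2cc(OCc3ccccc3)c(Cl)cc21`: 2.71
- compound 3 `C[C@@H](Oc1cc2oc(=O)n(CCC(=O)O)c2cc1Cl)c1cccnn1`: 0.83

Compound 3 sits at the low end of these numbers, and two steps place it: a number 0.05 log units lower from compound 1 to compound 3 (within the scatter), and a number 1.88 log units lower from compound 2 to compound 3 (beyond the scatter). Compound 4 `O=C(O)CCn1c(=O)oc2cc(OCc3ccccn3)c(Cl)cc21` differs from it in one place, on an oxygen on an aromatic ring: a group of 7 heavy atoms (6 carbon, 1 nitrogen; one six-membered aromatic ring with 1 hetero atom) in place of a group of 8 heavy atoms (6 carbon, 2 nitrogen; one six-membered aromatic ring with 2 hetero atoms), on an oxygen on an aromatic ring.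

The most useful guide is the large a number 1.88 log units lower from compound 2 to compound 3 (beyond the scatter), where a six-membered aromatic ring of carbon only gives way to one with 2 hetero atoms. The large a number 1.83 log units higher from compound 1 to compound 2 (beyond the scatter) also shows how far a change in this group can move the number. The ring of compound 4, with 1 hetero atom, falls between those of compound 2 and compound 3 by this count. Going by the values given here, no measured compound here carries such a ring, so part of the drop is only expected to return. The expected change is a moderate rise, beyond the scatter: a number 0.57 log units higher from compound 3 to compound 4 (beyond the scatter). For compound 4 the estimate is 1.4, with an expected range of 1 to 1.9.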

Compound 4, distribution coefficient: 1.32
Estimate against measurement, compound 4: 0.08 log units above, within the range that was stated.
By their numbers in this assay, from the lowest: compounds 3 and 1 (each within the scatter of the next); then compound 4; then compound 2.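

In this assay, replacing phenyl with pyridin-2-yl on the saturated chain carbon isolates a single change in the ring, and that change alone moves the number by a large amount (a number 1.39 log units lower from compound 2 to compound 4 (beyond the scatter)). The same pyridin-2-yl group still reads higher than the open methoxymethyl chain (a number 0.44 log units higher from compound 1 to compound 4 (beyond the scatter)), so this position now has a measured middle point, while the step up from the ring with 2 hetero atoms is modest (a number 0.49 log units higher from compound 3 to compound 4 (beyond the scatter)) and also removes a defined stereocentre, so it changes more than the ring. No supporting measurement is available to explain the size of these steps.

The compounds shown leave open how much of that last step comes from the ring and how much from the methyl on the chain carbon. They also leave open how pyridin-3-yl or pyridin-4-yl would compare with pyridin-2-yl on the same chain carbon.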